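The source may report more compounds than this note shows. Statements on the series, on what has been measured and on what is new or still open speak of the compounds shown alone.

Measured so far, in a functional assay on Jurkat cells (Homo sapiens) for inhibition; a higher number here means a weaker inhibitor, a lower number a stronger inhibitor:

Compound 1, `CC(C)[C@H](NC(=O)COc1cccc2ccccc12)C(=O)N[C@@H](CC(=O)O)C(=O)CSc1nc[nH]n1`: > 200000 nM, a limit of the assay.
Compound 2, `CC(C)[C@H](NC(=O)COc1cccc2ccccc12)C(=O)N[C@@H](CC(=O)O)C(=O)CSc1nncn1C`: > 200000 nM, a limit of the assay.
Compound 3, `CC(C)[C@H](NC(=O)COc1cccc2ccccc12)C(=O)N[C@@H](CC(=O)O)C(=O)COc1ccccn1`: > 200000 nM, a limit of the assay.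

Compound 1 therefore stands at a limit and not at a number, like the two others; all three sit at the limit of > 200000 nM in this assay, at which 3 of the 3 values shown sit. The steps a step that the two limits leave unreadable from compound 1 to compound 2, a step that the two limits leave unreadable from compound 1 to compound 3 and a step that the two limits leave unreadable from compound 2 to compound 3 are accordingly unreadable in size and direction.

Compound 4, `CC(C)[C@H](NC(=O)COc1cccc2ccccc12)C(=O)N[C@@H](CC(=O)O)C(=O)COc1cc(C(F)(F)F)ncn1`, differs from compound 1 by (6-(trifluoromethyl)pyrimidin-4-yl)oxy in place of (1H-1,2,4-triazol-3-yl)sulfanyl on a saturated chain carbon bound to a carbonyl carbon. The step nearest to it, from compound 1 to compound 3, is unreadable. The step of an at least 1.3-fold lower number from compound 1 to compound 4 (0.12 log units; that floor lies within the scatter) is expected, as an estimate only, and rests on no measured direction. Compound 4 is expected at 150000 nM, between 20000 nM and 600000 nM, most likely again reported as a limit.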

Compound 4, half-maximal inhibitory concentration: > 200000 nM
Compound 4 ended at the assay's limit; the forecaster's own chance of this, stated with the estimate: 70%; at least 1.3-fold (0.12 log units) between middle value and limit.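

Going by these compounds alone, compound 4 gives > 200000 nM, a limit of the assay, and no step to it from compound 1, compound 2 or compound 3 can be read: the limit of > 200000 nM in this assay, at which 4 of the 4 values shown sit.

In this assay the compounds shown leave open whether any of these groups on the saturated chain carbon changes inhibition at all.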